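The source may hold more compounds than are shown below. What is called first, only, known or untested is meant among the compounds shown, and "the series" means these compounds.

The measured compounds are:
compound 1, `COc1cc(-c2cc(/C=C/C(=O)c3ccc(N)cc3)[nH]n2)cc(OC)c1OC`, which in a functional assay on HOP-62 cells (Homo sapiens) for inhibition, read by sulforhodamine B assay, with a stated time of 48 h (on this read-out higher numbers stand for lower toxicity in this test and lower numbers for higher toxicity in this test), gives 8700 nM;
compound 2, `COc1ccc(C(=O)/C=C/c2cc(-c3cc(OC)c(OC)c(OC)c3)n[nH]2)cc1OC`, which in this assay gives 5350 nM.

Among the measured compounds shown here, of these two numbers compound 2 has the lowest, and its nearest neighbour is compound 1; the only measured step, a 1.6-fold lower number from compound 1 to compound 2 (0.21 log units; within the scatter), lies within the scatter, so the two compounds cannot be told apart on this test. Compound 3, `COc1cc(C(=O)/C=C/c2cc(-c3cc(OC)c(OC)c(OC)c3)n[nH]2)cc(OC)c1OC`, is not yet measured. It differs from compound 2 by methoxy in place of hydrogen on an aromatic carbon; the new group enters on an aromatic carbon of a six-membered aromatic ring of carbon only, ortho to a methoxy group already present. For the measured compounds named here, no measured step adds a methoxy group in this way. Going by the values given here, the one step available replaced 4-aminophenyl by 3,4-dimethoxyphenyl on a carbonyl carbon and still stayed within the scatter, so a change at that part of the molecule did not move the number in this assay beyond the scatter. A further methoxy group is therefore expected to shift the number little: the estimated step is a 1.2-fold lower number from compound 2 to compound 3 (0.08 log units; within the scatter), within the scatter. Compound 3 is expected to give about 4500 nM, with a likely range from 1500 nM to 14000 nM.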

Compound 3, concentration lethal to 50% of the cells: 5740 nM
Compound 3: the middle estimate sits 1.3-fold (0.11 log units) below what was measured; measured number inside the range.
By their numbers in this assay, from the lowest: compounds 2, 3 and 1 (each within the scatter of the next).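

In this assay, methoxy in place of hydrogen on an aromatic carbon, ortho to a methoxy group, gives a 1.1-fold higher number from compound 2 to compound 3 (0.03 log units; within the scatter) and so leaves the two compounds indistinguishable on this test. Among the compounds shown here, this is the first measured step that adds a single small group to the ring on the carbonyl carbon, whereas the earlier step exchanged the whole aryl group, so it tests this one position directly. Among the compounds shown, a further methoxy group at this position therefore makes no readable difference, although no measurement shown bears on the reason for this.

As far as these compounds go, a single group at one position cannot show how far this lack of effect extends, so it remains open whether a hydroxy group, an amine or a fluorine atom on the same aromatic carbon would move the number beyond the scatter. From the compounds shown here alone, it also remains open whether the same holds for methoxy groups on the other aromatic ring of the core, or for a longer chain such as ethoxy in place of methoxy at this position.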